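This account rests on a few compounds, and the source may have more. Where it says the series, first, only, none or still open, it means among the compounds named here.

Measured in a functional assay on SW480 cells (Homo sapiens) for inhibition; a higher number here means a weaker inhibitor of growth, a lower number a stronger inhibitor of growth:
compound 1 `Cc1c(C(=O)Nc2ccc3ccccc3n2)cnn1-c1ccccc1`: 23900 nM
compound 2 `Cc1c(C(=O)Nc2ccc3ccccc3n2)cnn1-c1ccccc1F`: 33300 nM
compound 3 `Cc1c(C(=O)Nc2ccc3ccccc3n2)cnn1-c1cccc(Cl)c1F`: 9000 nM

Compound 1 stands second highest of the three numbers; compound 2 lies nearest, a 1.4-fold higher number from compound 1 to compound 2 (0.14 log units; within the scatter), and compound 3 furthest, a 2.7-fold lower number from compound 1 to compound 3 (0.42 log units; beyond the scatter). Between the other two the step is a 3.7-fold lower number from compound 2 to compound 3 (0.57 log units; beyond the scatter).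

Compound 4 `CC(C)c1c(C(=O)Nc2ccc3ccccc3n2)cnn1-c1ccccc1` differs from compound 1 by isopropyl in place of methyl on an aromatic carbon. Among the measured compounds shown here, none of the measured steps bears on this change: all three alter the phenyl group on the aromatic nitrogen, and the carbon carrying the methyl is left untouched in every measured pair. For the measured compounds named here, with no step to lean on, the step of a 1.0-fold higher number from compound 1 to compound 4 (0.00 log units; within the scatter) is expected to stay within the scatter, in no preferred direction. Compound 4 is estimated at 24000 nM in this assay, with a range from 7000 nM to 80000 nM.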

Compound 4, concentration for 50% growth inhibition: 17300 nM
Estimate against measurement, compound 4: 1.4-fold (0.14 log units) above, within the range that was stated.
By their numbers in this assay, from the lowest: compounds 3, 4, 1 and 2 (each within the scatter of the next, the first and the last beyond it).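

Among the compounds shown here, at the aromatic carbon next to the ring nitrogen, a position the earlier steps left untouched, isopropyl in place of methyl gives no change beyond the scatter in this assay: a 1.4-fold lower number from compound 1 to compound 4 (0.14 log units; within the scatter). For the compounds shown here, this position therefore accepts the branched group without a readable gain or loss, whereas the only steps beyond the scatter so far lie on the phenyl group. Nothing measured here accounts for this result.

Going by these compounds, how a hydrogen, a cyclopropyl ring, a tert-butyl group or an amine would behave at this carbon remains open. Also open, on these data alone, is whether isopropyl here adds to the 3-chloro-2-fluorophenyl group of compound 3.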